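Aryl substituent on the ring nitrogen and potency

This account rests on a few compounds, and the source may have more. Where it says the series, first, only, none or still open, it means among the compounds named here.

Compound 1 `COc1cccc(OC)c1N1C(=O)CSC1c1cccc(C(=O)NCCCCc2ccccc2)c1`: > 1000 nM
Compound 2 `CCN1C(=O)CSC1c1cccc(C(=O)NCCCCc2ccccc2)c1`: > 1000 nM
Compound 3 `COc1c(F)cccc1N1C(=O)CSC1c1cccc(C(=O)NCCCCc2ccccc2)c1`: 26.2 nM

Within the data shown here, in a functional assay on HOS-TE85 cells (Homo sapiens) for inhibition, read by CCK-8 assay, with a stated time of 72 h (on this read-out lower numbers stand for stronger inhibition and higher numbers for weaker inhibition), compound 3 gives 26.2 nM, the only number among the three values shown. The value of compound 1 is a limit of this assay, not a number. The value of compound 2 is likewise a limit. Compound 4 `O=C(NCCCCc1ccccc1)c1cccc(C2SCC(=O)N2c2ccccc2)c1` differs from compound 3 in one place: phenyl in place of 3-fluoro-2-methoxyphenyl on an amide-type nitrogen in a ring.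

Among the measured compounds shown here, two measured steps bear on this change, both at the same position. For the measured compounds named here, the step of an at least 38-fold lower number from compound 1 to compound 3 (1.58 log units; beyond the scatter) and the step of an at least 38-fold lower number from compound 2 to compound 3 (1.58 log units; beyond the scatter) show that the 3-fluoro-2-methoxyphenyl group is tied to the only readable number here, while both other groups at this nitrogen sit at the limit of > 1000 nM in this assay, at which 2 of the 3 values shown sit. Phenyl is a third group at the same place, and none of the shown compounds carries it. A weaker number than that of compound 3 is therefore expected for compound 4, with a step of an 11-fold higher number from compound 3 to compound 4 (1.06 log units; beyond the scatter). Compound 4 is estimated at 300 nM, within 50 nM to 2000 nM.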

Compound 4, half-maximal inhibitory concentration: 15.9 nM
Compound 4: middle estimate off by 19-fold (1.28 log units), on the high side; measured number outside the range, below it.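

In this assay, replacing 3-fluoro-2-methoxyphenyl with phenyl gives a 1.6-fold lower number from compound 3 to compound 4 (0.22 log units; within the scatter), so the methoxy and fluoro groups of compound 3 are not needed for a readable number at this nitrogen. Phenyl also separates clearly from the ethyl group, with an at least 62-fold lower number from compound 2 to compound 4 (1.79 log units; beyond the scatter), and from the 2,6-dimethoxyphenyl group, with an at least 62-fold lower number from compound 1 to compound 4 (1.79 log units; beyond the scatter), yet compound 1 shows that an aromatic ring here is not enough on its own. The values of compound 1 and compound 2 are limits, not numbers: the limit of > 1000 nM in this assay, at which 2 of the 4 values shown sit.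

The compounds shown leave open whether a 2-methoxyphenyl, a 3-fluorophenyl, a pyridyl or a benzyl group at this nitrogen would stay level with phenyl. They also leave open which of the two methoxy groups of compound 1 goes with its loss of a readable number.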